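The source may hold more compounds than are shown below. What is called first, only, known or untested is meant among the compounds shown, and "the series" means these compounds.

Measured compounds:
compound 1 `COc1ccc(-c2cn(Cc3ccccc3)nn2)cc1`, 231000 nM
compound 2 `Cc1ccc(-c2cn(Cc3ccccc3)nn2)cc1`, 253000 nM

In a functional assay on MCF7 cells (Homo sapiens) for antiproliferative activity, read by MTT assay, with a stated time of 72 h (on this read-out lower numbers stand for stronger inhibition and higher numbers for weaker inhibition), compound 2 gives 253000 nM, the higher of the two numbers shown, but the step of a 1.1-fold higher number from compound 1 to compound 2 (0.04 log units; within the scatter) lies within the scatter, so no real difference between the two can be claimed. Compound 3 `FC(F)(F)c1ccc(-c2cn(Cc3ccccc3)nn2)cc1` is not yet measured. It differs from compound 2 by trifluoromethyl in place of methyl on an aromatic carbon. Among the compounds with values here, the only measured step that bears on this change is a 1.1-fold higher number from compound 1 to compound 2 (0.04 log units; within the scatter), in which one small group replaced another on the same aromatic carbon and the number barely moved. On that basis no step beyond the scatter is expected in this assay in either direction, although a single prior step is a thin basis. Compound 3 is therefore estimated at 230000 nM, with a range from 90000 nM to 550000 nM. This corresponds to an expected step of a 1.1-fold lower number from compound 2 to compound 3 (0.04 log units; within the scatter).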

Compound 3, half-maximal inhibitory concentration: 162000 nM
Compound 3: the middle estimate sits 1.4-fold (0.15 log units) above what was measured, and the stated range covers the measured number.
By their numbers in this assay, from the lowest: compounds 3, 1 and 2 (each within the scatter of the next).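

Trifluoromethyl is a third group on this aromatic carbon, para to a large group, and in this assay it gives a 1.6-fold lower number from compound 2 to compound 3 (0.19 log units; within the scatter), and also a 1.4-fold lower number from compound 1 to compound 3 (0.15 log units; within the scatter). Methoxy, methyl and trifluoromethyl therefore cannot be told apart at this position in this assay, even though the three groups differ in their atoms, so this change gives no real shift in the number. No supporting measurement is available to account for this flat result.

Going by these compounds, it remains open whether a group of another kind on this carbon, such as an amine, a carboxylic acid or a longer chain, would move the number beyond the scatter. On these data alone, it is equally open whether a change elsewhere on the shared core would do so.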